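Small Changes on a Shared Core and Cell Growth

The source may report more compounds than this note shows. Statements on the series, on what has been measured and on what is new or still open speak of the compounds shown alone.

Compound 1 `CN1C(=O)C(O)(Cc2nnn[nH]2)c2cc(Cl)ccc21` gives 76000 nM in a functional assay on DU-145 cells (Homo sapiens) for antiproliferative activity, read by MTT assay, with a stated time of 48 h; a lower number here means a stronger inhibitor, a higher number a weaker inhibitor.
Compound 2 `CCN1C(=O)C(O)(Cc2nnn[nH]2)c2cc(Cl)ccc21` gives 21500 nM in this assay.
Compound 3 `Cc1ccc2c(c1)C(O)(Cc1nnn[nH]1)C(=O)N2C` gives > 100000 nM in this assay.

For compound 3 that entry is a limit of this assay, not a number, (the limit of > 100000 nM in this assay, at which 1 of the 3 values shown sits). Compound 1 and compound 2 differ by methyl in place of hydrogen on a saturated chain carbon bound to an amide-type nitrogen in a ring, a change that gave a 3.5-fold lower number from compound 1 to compound 2 (0.55 log units; beyond the scatter). Compound 1 and compound 3 differ in their cores by methyl in place of chloro on an aromatic carbon, giving an at least 1.3-fold higher number from compound 1 to compound 3 (0.11 log units; that floor lies within the scatter).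

Compound 4 `CCN1C(=O)C(O)(Cc2nnn[nH]2)c2cc(C)ccc21` is not yet measured. It differs from compound 3 by methyl in place of hydrogen on a saturated chain carbon bound to an amide-type nitrogen in a ring, the same change at the same place as between compound 1 and compound 2. In this assay compound 4 is therefore expected to show a step of an at least 2.5-fold lower number from compound 3 to compound 4 (0.39 log units; beyond the scatter), resting on a 3.5-fold lower number from compound 1 to compound 2 (0.55 log units; beyond the scatter), applied from a starting point that is only a limit. The estimated value for compound 4 is 40000 nM, expected to lie between 20000 nM and 100000 nM.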

Compound 4, half-maximal inhibitory concentration: 14600 nM
Compound 4: middle estimate off by 2.7-fold (0.44 log units), on the high side; the measured number lies below the stated range.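

In this assay, going from methyl to ethyl on the core of compound 3 gives an at least 6.8-fold lower number from compound 3 to compound 4 (0.83 log units; beyond the scatter) and so points the same way as on the core of compound 1. For compound 3 the entry of > 100000 nM is a limit of the assay, not a number. The result therefore shows that the direction carries over to this second core, but not whether the size does: the same change on two cores in this assay, a 3.5-fold lower number (0.55 log units; beyond the scatter) from compound 1 to compound 2 and an at least 6.8-fold lower number (0.83 log units; beyond the scatter) from compound 3 to compound 4; the limit leaves it open whether they differ.

Among these compounds, the effect of methyl in place of chloro on an aromatic carbon stays unsettled, with a 1.5-fold lower number from compound 2 to compound 4 (0.17 log units; within the scatter) as the only exact comparison. Also open, on these data alone, is how a longer chain such as propyl, or an amine on that aromatic carbon, would behave.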